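The compounds below may be only part of what the source reports. "The series", "measured", "known", "first", "only" and "open" are said of these compounds alone.

Compound 3 `CN(C)CCCCCSC1=Nc2ccccc2C(CC(=O)NCc2ccccc2)N1c1ccccc1` is the simplest member of the set. In a functional assay on A549 cells (Homo sapiens) for cytotoxicity, read by MTT assay, with a stated time of 48 h (a higher number here means a weaker inhibitor, a lower number a stronger inhibitor), compound 3 gives 138000 nM. Compound 1 `CN(C)CCCCCSC1=Nc2ccccc2C(CC(=O)NCc2ccccc2)N1c1ccc(-c2ccc(F)cc2)cc1` carries 4-fluorophenyl in place of hydrogen on an aromatic carbon; in this assay compound 1 gives 17600 nM, which is a step of a 7.8-fold lower number from compound 3 to compound 1 (0.89 log units; beyond the scatter). Compound 2 `CN(C)CCCCCSC1=Nc2ccccc2C(CC(=O)NCc2ccc(F)cc2)N1c1ccccc1` differs from compound 3 by fluoro in place of hydrogen on an aromatic carbon; in this assay compound 2 gives 36800 nM, and the step from compound 2 to compound 3 is a 3.8-fold higher number from compound 2 to compound 3 (0.57 log units; beyond the scatter). Among the compounds with values here, no step is counted between compound 1 and compound 2, but their two values show compound 2 standing at the higher number.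

Compound 4 `CN(C)CCCCCSC1=Nc2ccccc2C(CC(=O)NCc2ccc(F)cc2)N1c1ccc(-c2ccc(F)cc2)cc1` has not yet been measured in this assay. Relative to compound 2 it carries 4-fluorophenyl in place of hydrogen on an aromatic carbon, which is the same change as the one from compound 3 to compound 1, with the place described in identical words in both pairs. The two cores on which this change is made differ only by the fluoro in place of hydrogen on an aromatic carbon already noted between compound 3 and compound 2.

Compound 4 is expected to move from compound 2 by a 6.7-fold lower number from compound 2 to compound 4 (0.83 log units; beyond the scatter), a step close to the earlier one, since the only comparable pairing, a 7.8-fold lower number from compound 3 to compound 1 (0.89 log units; beyond the scatter), shows this change lowering the number well beyond the scatter. Compound 4 is therefore estimated at 5500 nM, with a plausible range from 2000 nM to 15000 nM.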

Compound 4, half-maximal inhibitory concentration: 11300 nM
Beside the measured number, compound 4's estimate is 2.1-fold (0.31 log units) below it; the measured number falls inside the stated range.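

In this assay, 4-fluorophenyl in place of hydrogen again lowers the number on the core that carries the fluoro group, a 3.3-fold lower number from compound 2 to compound 4 (0.51 log units; beyond the scatter), so the change keeps its direction on both cores, and the sizes of the two steps agree within the scatter: the same change on two cores in this assay, a 7.8-fold lower number (0.89 log units; beyond the scatter) from compound 3 to compound 1 and a 3.3-fold lower number (0.51 log units; beyond the scatter) from compound 2 to compound 4, 2.4-fold (0.38 log units) apart, within the scatter of two such steps

The fluoro change, by contrast, gives a 1.6-fold lower number from compound 1 to compound 4 (0.19 log units; within the scatter), which lies within the scatter, although on the simpler core its step lay beyond it, and the gap between these two steps is itself within the scatter: the same change on two cores in this assay, a 3.8-fold higher number (0.57 log units; beyond the scatter) from compound 2 to compound 3 and a 1.6-fold higher number (0.19 log units; within the scatter) from compound 4 to compound 1, 2.4-fold (0.38 log units) apart, within the scatter of two such steps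

All of this rests on two pairs in a single cell assay, so it shows that the 4-fluorophenyl step carried over between these two closely related cores, but not that its size is fixed or that it would carry over to any other core.

The compounds shown leave open whether a chloro or methoxy group, or a pyridine ring in place of 4-fluorophenyl, would lower the number in the same way. Also open, as far as these compounds go, is whether the step would hold with a shorter chain carrying the dimethylamino group, or with a morpholine in place of that amine, and whether it extends to other cell lines.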